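Working notes: ester to hydroxyethyl amide, compound 2 to compound 3

This account rests on a few compounds, and the source may have more. Where it says the series, first, only, none or still open, it means among the compounds named here.

Two members of the series carry results in a functional assay (strain AB) with Danio rerio as the target, read by microscopy, with a stated time of 1 h; on this read-out lower numbers stand for an effect already at smaller amounts and higher numbers for an effect only at larger amounts of compound. Compound 1 `CC(C)(C)OC(=O)CCCC[N+]1(C)CCc2c(sc(NC(=O)Nc3ccc(Cl)cc3)c2C(N)=O)C1` gives 140 nM in this assay. Compound 2 `CCN1CCc2c(sc(NC(=O)Nc3ccc(Cl)cc3)c2C(=O)OC)C1` returns only a limit in this assay, > 25000 nM. The limit line the limit of > 25000 nM in this assay, at which 1 of the 2 values shown sits, is where compound 2 sits, so it stands at the weak end of what has been measured, with no number of its own. Compound 1 and compound 2 differ in several places at once, so their two values show only that the series spans from a clear effect to none within the tested range.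

Compound 3 `CCN1CCc2c(sc(NC(=O)Nc3ccc(Cl)cc3)c2C(=O)NCCO)C1` follows from compound 2 by a single change: (2-hydroxyethyl)amino in place of methoxy on a carbonyl carbon. Within the data shown here, no measured pair isolates this change, so its size has to be guessed. The step the estimate means, an at least 4.1-fold lower number from compound 2 to compound 3 (0.61 log units; beyond the scatter), is expected to run toward lower numbers and beyond the scatter, with a second limit remaining a real possibility. Compound 3 is expected near 6000 nM, within 900 nM to 30000 nM.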

Compound 3, half-maximal effective concentration: 9400 nM
The estimate for compound 3 lay 1.6-fold (0.19 log units) below the measured number, and the stated range covers the measured number.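

Among these compounds, on the carbonyl carbon, the exchange of methoxy for (2-hydroxyethyl)amino is the first single change that can be read, and in this assay it gives an at least 2.6-fold lower number from compound 2 to compound 3 (0.42 log units; beyond the scatter). Compound 3 thereby gives this part of the series a number of its own, 9400 nM, and shows that this position alone can move the read-out with the rest of the structure held fixed, which compound 1 and compound 2 could not show, as they differ in several places. The step fixes only a minimum for the size of this change, and the value of compound 2 is a limit and not a number: the limit of > 25000 nM in this assay, at which 1 of the 3 values shown sits.

The compounds shown do not separate the contribution of the amide link from that of the terminal hydroxyl, as a methylamino or a 2-methoxyethylamino group on the same carbonyl carbon could. On these data alone, how a carboxylic acid or a longer hydroxyalkyl chain would read at this position also stays open.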